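Series notes: one chloro removed from compound 2

The source may hold more compounds than are shown below. What is called first, only, known or untested is meant among the compounds shown, and "the series" means these compounds.

Compound 2 `Clc1ccc(COc2ccc(/C=C/C(/C=C/c3ccccn3)=N/Oc3ncnc4ccccc34)cc2)c(Cl)c1` gives 89.6% in a functional assay on SMMC-7721 cells (Homo sapiens) for inhibition, read by MTT assay, with a stated time of 72 h, tested at 10 uM; a higher number here means a stronger effect of the compound at the concentration tested, a lower number a weaker effect. Among the three measured values it stands second highest. Compound 1 `Cc1cccc2ncnc(O/N=C(\C=C\c3ccccn3)/C=C/c3ccccc3OCc3ccc(Cl)cc3Cl)c12` gives 93.9%, and this lies within the scatter of the value of compound 2, so no order between the two is claimed. For the measured compounds named here, compound 3 `Clc1ccc(COc2ccc(/C=C/C(/C=C/c3ccccn3)=N/Oc3ncnc4cc(Cl)ccc34)cc2)c(Cl)c1` gives 23.6%; the step of a number 66 percentage points lower from compound 2 to compound 3 (beyond the scatter) is the only measured step that differs in one place, and it is large.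

Compound 4 `Clc1ccccc1COc1ccc(/C=C/C(/C=C/c2ccccn2)=N/Oc2ncnc3ccccc23)cc1` differs from compound 2 by hydrogen in place of chloro on an aromatic carbon. Going by the values given here, no measured step takes a chloro away from the 2,4-dichlorobenzyl group, so this change has no direct precedent. The step of a number 66 percentage points lower from compound 2 to compound 3 (beyond the scatter) concerns chloro at a different place and runs in the opposite direction; it shows only that a single chloro can shift this assay strongly. With that uncertainty, a moderate fall is expected, a number 17.6 percentage points lower from compound 2 to compound 4 (beyond the scatter). Compound 4 is therefore estimated at 72%, within a range from 35% to 95%.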

Compound 4, a percentage reported as inhibition, at one concentration (the size of the read-out at that concentration, not a potency): 96.9%
Compound 4: the middle estimate sits 24.9 percentage points below what was measured, and the stated range ends below it.
By their numbers in this assay, from the lowest: compound 3; then compounds 2, 1 and 4 (each within the scatter of the next).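

In this assay, the change from 2,4-dichlorobenzyl to 2-chlorobenzyl gives a number 7.3 percentage points higher from compound 2 to compound 4 (within the scatter), so the chloro at this position is not required for a high read-out at the concentration tested. Sensitivity to a single chloro therefore does not extend to every place in the series: the added chloro on the shared core gives a number 66 percentage points lower from compound 2 to compound 3 (beyond the scatter), while this change on the benzyl ring leaves the read-out within the scatter. Nothing measured on these compounds accounts for that contrast.

Open, from the compounds shown here alone, is whether the remaining chloro of the 2-chlorobenzyl group can also be exchanged, or whether a methoxy group or an amine is tolerated at the position vacated in compound 4. Going by these compounds, a single concentration gives no potency, so any potency difference between compound 2 and compound 4 also remains open.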